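Swapping a Hydroxyphenyl for a Methylphenyl on the Sulfonamide

A few compounds are considered here, and "the series" means these few. Any claim that something is new, unique, unknown or untested is made for them only; others in the source may bear on it.

Compound 1 `CC(C)(C)c1ccc(S(=O)(=O)Nc2ccccc2)cc1` gives 16000 nM in a functional assay on A549 cells (Homo sapiens) for inhibition; on this read-out lower numbers stand for stronger inhibition of growth and higher numbers for weaker inhibition of growth. Compound 2 `CC(C)(C)c1ccc(S(=O)(=O)Nc2cccc(O)c2)cc1` gives 12000 nM, and compound 3 `CC(C)(C)c1ccc(S(=O)(=O)Nc2ccc(O)cc2)cc1` gives 14000 nM, so compound 3 holds the second highest of the three numbers, with all three lying within the scatter of one another. Compound 4 `Cc1ccccc1NS(=O)(=O)c1ccc(C(C)(C)C)cc1` differs from compound 3 by 2-methylphenyl in place of 4-hydroxyphenyl on a sulfonamide nitrogen. The measured steps that bear on this change are a 1.1-fold lower number from compound 1 to compound 3 (0.06 log units; within the scatter) and a 1.2-fold higher number from compound 2 to compound 3 (0.07 log units; within the scatter), which show that adding or relocating a hydroxy on this ring barely moves the number. For the measured compounds named here, no measured step covers a methyl on this ring, yet from these two steps no change beyond the scatter is expected for compound 4 in this assay, whose number is estimated at 15000 nM, between 7000 nM and 32000 nM, a step of a 1.1-fold higher number from compound 3 to compound 4 (0.03 log units; within the scatter).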

Compound 4, concentration for 50% growth inhibition: > 80000 nM
Compound 4 gave a limit, no number; the forecaster's own chance of this, stated with the estimate: 10%; middle value at least 5.3-fold (0.72 log units) away from the limit.
By their numbers in this assay, from the lowest: compounds 2, 3 and 1 (each within the scatter of the next). At a limit, above all of these: compound 4.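

In this assay compound 4 gives a limit, not a number: the limit of > 80000 nM in this assay, at which 1 of the 4 values shown sits. A hydroxy on this ring moved the number by no more than the scatter, whereas 2-methylphenyl gives an at least 5.0-fold higher number from compound 1 to compound 4 (0.69 log units; beyond the scatter) and, against the two hydroxyphenyl compounds, an at least 5.7-fold higher number from compound 3 to compound 4 (0.75 log units; beyond the scatter) and an at least 6.6-fold higher number from compound 2 to compound 4 (0.82 log units; beyond the scatter), so the ring on the sulfonamide nitrogen does not accept every small change equally. As far as these compounds go, the true number for compound 4 stays unknown, so the full size of these steps remains open. Also open, from the compounds shown here alone, is how an ethyl, a methoxy or an amine on this ring would compare.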